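Swapping the aryl group on the triazole: compound 3 expected

The source may report more compounds than this note shows. Statements on the series, on what has been measured and on what is new or still open speak of the compounds shown alone.

In an ADME assay on PANC-1 cells (Homo sapiens) for cytotoxicity, read by sulforhodamine B assay, with a stated time of 48 h, tested at 10 uM (a higher number here means more inhibition at the concentration tested (going by the name of the read-out), a lower number less inhibition), compound 2 `COc1nc2ccc(Br)cc2cc1C(c1ccccc1)n1cc(-c2ccc(OC(F)(F)F)cc2)nn1` gives 11.7%. Its nearest neighbour, compound 1 `COc1nc2ccc(Br)cc2cc1C(c1ccccc1)n1cc(-c2ccccc2F)nn1`, gives 14.7%; the two numbers sit within the usual scatter of each other, so neither number can be called the higher. Compound 3 `COc1nc2ccc(Br)cc2cc1C(c1ccccc1)n1cc(-c2cccc(F)c2)nn1` differs from compound 2 in one place: 3-fluorophenyl in place of 4-(trifluoromethoxy)phenyl on an aromatic carbon. For the measured compounds named here, the only measured step that bears on this change, also an aryl swap on the same aromatic carbon, is a number 3 percentage points lower from compound 1 to compound 2 (within the scatter). Because a number 3 percentage points lower from compound 1 to compound 2 (within the scatter) stayed within the scatter, the expected step of a number 1.3 percentage points higher from compound 2 to compound 3 (within the scatter) is likewise none beyond the scatter. Compound 3 is therefore estimated at 13%, ranging from 3% to 25%.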

Compound 3, a percentage reported as inhibition, at one concentration (the size of the read-out at that concentration, not a potency): 15.5%
Estimate against measurement, compound 3: 2.5 percentage points below, within the range that was stated.
By their numbers in this assay, from the lowest: compounds 2, 1 and 3 (each within the scatter of the next).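

At this aromatic carbon, 3-fluorophenyl behaves like the two aryl groups before it. In this assay, replacing 4-(trifluoromethoxy)phenyl with it gives a number 3.8 percentage points higher from compound 2 to compound 3 (within the scatter), and replacing 2-fluorophenyl with it gives a number 0.8 percentage points higher from compound 1 to compound 3 (within the scatter). Among these compounds, then, neither moving the fluorine on the phenyl ring nor going from 11 heavy atoms to 7 shifts the reading beyond the scatter, and no measurement shown here offers an explanation. From the compounds shown here alone, all three groups are substituted phenyl rings, so it remains open whether an amine, a carboxylic acid or a longer alkyl chain at this carbon would change the reading.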